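The compounds below may be only part of what the source reports. "The series", "measured", "known", "first", "only" and "open" are said of these compounds alone.

Measured so far:
- compound 1 `C=CCc1cc(OC)c(OC(C)C(OC2CCCCC2)c2ccc(O)c(OC)c2)c(OC)c1`: 54 nM
- compound 2 `C=CCc1cc(OC)c(OC(C)C(OCCCCCCCCCC)c2ccc(O)c(OC)c2)c(OC)c1`: 66 nM
- compound 3 `C=CCc1cc(OC)c(OC(C)C(OCCCCCC)c2ccc(O)c(OC)c2)c(OC)c1`: 329 nM

In an assay on HEK293 cells for agonist activity at transient receptor potential cation channel subfamily M member 8 (Homo sapiens), read by fluorescence and calcium flux, with a stated time of 5 min (a higher number here means that more compound is needed for the effect, a lower number that less compound is needed), compound 1 stands at the lowest of the three numbers; compound 2 lies within the scatter of it, with a 1.2-fold higher number from compound 1 to compound 2 (0.09 log units; within the scatter), while compound 3 sits well apart, with a 6.1-fold higher number from compound 1 to compound 3 (0.78 log units; beyond the scatter). Compound 4 `C=CCc1cc(OC)c(OC(C)C(O[C@H]2C[C@@H](C)CC[C@@H]2C(C)C)c2ccc(O)c(OC)c2)c(OC)c1` differs from compound 1 by a group of 10 heavy atoms (10 carbon; one six-membered non-aromatic ring of carbon only) in place of a group of 6 heavy atoms (6 carbon; one six-membered non-aromatic ring of carbon only), on an oxygen on a saturated carbon.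

Going by the values given here, the steps that bear on this are those at the same oxygen: a 1.2-fold higher number from compound 1 to compound 2 (0.09 log units; within the scatter) and a 6.1-fold higher number from compound 1 to compound 3 (0.78 log units; beyond the scatter). Both groups entering there in the measured set kept or lost activity relative to cyclohexyl, and the closer of them in size gave no shift beyond the scatter. Among the compounds with values here, no step within the set is expected to predict a gain here, so compound 4 is estimated to hold roughly the level of compound 1, with a 1.2-fold lower number from compound 1 to compound 4 (0.08 log units; within the scatter). The estimate for compound 4 is 45 nM, expected between 15 nM and 150 nM.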

Compound 4, half-maximal effective concentration: 11 nM
For compound 4 the middle estimate is 4.1-fold (0.61 log units) above the measured one, and the stated range ends above it.
By their numbers in this assay, from the lowest: compound 4; then compounds 1 and 2 (each within the scatter of the next); then compound 3.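

In this assay, the ring group with its defined stereocentres on this oxygen goes past cyclohexyl (a 4.9-fold lower number from compound 1 to compound 4 (0.69 log units; beyond the scatter)), so a larger ring here can lower the number, which neither chain had done. At the same count of heavy atoms, the ring group also differs clearly from decyl (a 6.0-fold lower number from compound 2 to compound 4 (0.78 log units; beyond the scatter)), so that count alone does not set the number; the gap from hexyl is larger still (a 30-fold lower number from compound 3 to compound 4 (1.48 log units; beyond the scatter)). Open, going by these compounds, is whether the stereocentres matter and whether a ring carrying an amine or a carboxylic acid on this oxygen would hold this level. No evidence at hand accounts for these shifts.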